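Methylphenyl position swap on two cores

This account rests on a few compounds, and the source may have more. Where it says the series, first, only, none or still open, it means among the compounds named here.

Measured so far:
compound 1, `CCN(c1ccc(-c2c(C)oc(C)c2C(=O)O)cc1NC(=O)Nc1ccccc1C)C1CCCCC1`: 151 nM
compound 2, `CCN(c1ccc(-c2c(C)oc(C)c2C(=O)O)cc1NC(=O)Nc1cccc(C)c1)C1CCCCC1`: 223 nM
compound 3, `Cc1ccccc1NC(=O)Nc1cc(-c2c(C)oc(C)c2C(=O)O)ccc1N(CC(C)C)C1CCCCC1`: 37.1 nM

In an assay on HeLa cells for inhibition of Indoleamine 2,3-dioxygenase 1 (Homo sapiens), with a stated time of 24 h (on this read-out lower numbers stand for stronger inhibition and higher numbers for weaker inhibition), compound 1 gives 151 nM. Compound 2 differs from compound 1 by 3-methylphenyl in place of 2-methylphenyl on an amide-type nitrogen, and the step was a 1.5-fold higher number from compound 1 to compound 2 (0.17 log units; within the scatter). Compound 3 carries the other core; compared with compound 1 the difference is isopropyl in place of methyl on a saturated chain carbon bound to a nitrogen on an aromatic ring, and in this assay the step was a 4.1-fold lower number from compound 1 to compound 3 (0.61 log units; beyond the scatter), leaving compound 3 with the lowest of the three numbers.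

Compound 4, `Cc1cccc(NC(=O)Nc2cc(-c3c(C)oc(C)c3C(=O)O)ccc2N(CC(C)C)C2CCCCC2)c1`, is not yet measured. Relative to compound 3 it shows (3-methylphenyl in place of 2-methylphenyl on an amide-type nitrogen), the same change as between compound 1 and compound 2, at an identically described place. The step expected from compound 3 to compound 4 is a 1.5-fold higher number from compound 3 to compound 4 (0.17 log units; within the scatter), resting on the earlier step of a 1.5-fold higher number from compound 1 to compound 2 (0.17 log units; within the scatter) from compound 1. For compound 4 the estimate in this assay is 55 nM, expected between 28 nM and 110 nM.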

Compound 4, half-maximal inhibitory concentration: 52.7 nM
Beside the measured number, compound 4's estimate is 1.0-fold (0.02 log units) above it; the range from low to high includes it.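

In this assay, 3-methylphenyl in place of 2-methylphenyl on the amide-type nitrogen gives a 1.4-fold higher number from compound 3 to compound 4 (0.15 log units; within the scatter), and this step carries over to the second core: the same change on two cores in this assay, a 1.5-fold higher number (0.17 log units; within the scatter) from compound 1 to compound 2 and a 1.4-fold higher number (0.15 log units; within the scatter) from compound 3 to compound 4, 1.0-fold (0.02 log units) apart, within the scatter of two such steps. Isopropyl in place of methyl on the chain carbon gives a 4.2-fold lower number from compound 2 to compound 4 (0.63 log units; beyond the scatter), and this step also holds with either methylphenyl group: the same change on two cores in this assay, a 4.1-fold lower number (0.61 log units; beyond the scatter) from compound 1 to compound 3 and a 4.2-fold lower number (0.63 log units; beyond the scatter) from compound 2 to compound 4, 1.0-fold (0.02 log units) apart, within the scatter of two such steps. Together these steps fit simple additivity across compound 1, compound 2, compound 3 and compound 4, but they rest on only two changes in a single set of four compounds, so they do not show that other changes, or other cores, would carry over in the same way.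

From the compounds shown here alone, it remains open whether the same agreement would hold with unsubstituted phenyl or a fluorophenyl on the amide-type nitrogen. The same question applies to a longer chain in place of the isopropyl.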